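Dithiocarbamate benzamides: amine swap on the thiocarbonyl carbon

The source may report more compounds than this note shows. Statements on the series, on what has been measured and on what is new or still open speak of the compounds shown alone.

Measured so far:
compound 1 `Nc1ccccc1NC(=O)c1ccc(CSC(=S)N2CCc3cc([N+](=O)[O-])ccc32)cc1`: 26.8%
compound 2 `CC1CCCCN1C(=S)SCc1ccc(C(=O)Nc2ccccc2N)cc1`: 64.4%
compound 3 `CN(Cc1cccnc1)C(=S)SCc1ccc(C(=O)Nc2ccccc2N)cc1`: 45.9%

In a functional assay on MGC-803 cells (Homo sapiens) for antiproliferative activity, read by CCK-8 assay, with a stated time of 72 h, tested at 2 uM (a lower number here means a weaker effect, a higher number a stronger effect of the compound at the concentration tested), compound 3 stands second highest of the three numbers, below compound 2 and above compound 1, both gaps beyond the scatter. Compound 4 `Nc1ccccc1NC(=O)c1ccc(CSC(=S)N2CCc3cc(Cl)ccc32)cc1` differs from compound 3 in one place: 5-chloro-2,3-dihydro-1H-indol-1-yl in place of methyl((pyridin-3-yl)methyl)amino on a thiocarbonyl carbon. Within the data shown here, the only measured step at this position, a number 18.5 percentage points lower from compound 2 to compound 3 (beyond the scatter), shows that exchanging the amine on the thiocarbonyl carbon shifts the read-out beyond the scatter. Among the measured compounds shown here, no step between compound 1 and compound 3 is given; among the measured compounds the closest structural neighbour of compound 4 is compound 1, which gives 26.8%, lower than compound 3. A modest downward step is therefore expected, a number 10.9 percentage points lower from compound 3 to compound 4 (beyond the scatter). Compound 4 is estimated at 35%, between 15% and 58%.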

Compound 4, a percentage reported as inhibition, at one concentration (the size of the read-out at that concentration, not a potency): 57.7%
Beside the measured number, compound 4's estimate is 22.7 percentage points below it; low and high end bracket the measured number.
By their numbers in this assay, from the lowest: compound 1; then compound 3; then compounds 4 and 2 (each within the scatter of the next).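

In this assay the substituent on the aromatic carbon of the amine part counts: chloro in place of nitro gives a number 30.9 percentage points higher from compound 1 to compound 4 (beyond the scatter). An amine exchange can also raise the read-out, with a number 11.8 percentage points higher from compound 3 to compound 4 (beyond the scatter) in the change from methyl((pyridin-3-yl)methyl)amino to 5-chloro-2,3-dihydro-1H-indol-1-yl, while a number 6.7 percentage points lower from compound 2 to compound 4 (within the scatter) leaves that group and 2-methylpiperidin-1-yl unseparated. Nothing available explains these differences.

Open, going by these compounds, is how methoxy or fluoro would read on that aromatic carbon. Also open, on these data alone, is whether the unsubstituted 2,3-dihydro-1H-indol-1-yl group reads nearer compound 1 or compound 4.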